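Swapping One Furan for Another in a Cell Assay

A few compounds are considered here, and "the series" means these few. Any claim that something is new, unique, unknown or untested is made for them only; others in the source may bear on it.

Among the measured compounds shown here, two related compounds have numbers so far. In a functional assay on K562 cells (Homo sapiens), read by MTT assay, with a stated time of 72 h (on this read-out higher numbers stand for weaker inhibition and lower numbers for stronger inhibition), compound 1 (`CSc1ncnc2c1c(-c1ccoc1)cn2[C@@H]1O[C@H](CO)[C@@H](O)[C@H]1O`) gives 60 nM, while compound 2 (`CNc1ncnc2c1c(-c1ccco1)cn2[C@@H]1O[C@H](CO)[C@@H](O)[C@H]1O`) gives 220 nM. Compound 2 therefore holds the higher of the two numbers, making it the weaker inhibitor, and the gap lies beyond the usual scatter of repeated measurements.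

Compound 3 (`CNc1ncnc2c1c(-c1ccoc1)cn2[C@@H]1O[C@H](CO)[C@@H](O)[C@H]1O`) has not yet been measured. It differs from compound 2 in one place: furan-3-yl in place of furan-2-yl on an aromatic carbon. Furan-3-yl takes the place of furan-2-yl on an aromatic carbon, so the same atoms are simply joined differently.

For the measured compounds named here, no two measured compounds differ by this swap alone, so the data give no direct measure of its effect. Going by the values given here, the only guide is compound 1, which also carries furan-3-yl and gives 60 nM. In this assay the expected step of a 1.6-fold lower number from compound 2 to compound 3 (0.20 log units; within the scatter) is therefore small, towards a lower number, and not clearly beyond the scatter. For compound 3 the estimated value is 140 nM, with an expected range from 45 nM to 450 nM.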

Compound 3, half-maximal inhibitory concentration: > 20000 nM
Compound 3: a limit, no number (the forecaster's own chance of this, stated with the estimate: 3%); middle value at least 140-fold (2.15 log units) away from the limit.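

In this assay the entry for compound 3 is a limit of the assay and not a number: the limit of > 20000 nM in this assay, at which 1 of the 3 values shown sits.

Even so, the change of furan-2-yl to furan-3-yl, on an aromatic carbon of the five-membered ring, gives an at least 90-fold higher number from compound 2 to compound 3 (1.95 log units; beyond the scatter), which shows that this position can respond strongly to how the furan is joined, although the swap leaves the atoms and the counts of hydrogen-bond donors and acceptors the same. The second step shows that furan-3-yl alone does not settle the outcome, since methylamino in place of methylsulfanyl gives an at least 330-fold higher number from compound 1 to compound 3 (2.52 log units; beyond the scatter), so the group on the other aromatic carbon also counts for a great deal when furan-3-yl is present.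

The compounds shown leave open how furan-2-yl behaves alongside methylsulfanyl, so it remains unclear whether the furan swap would have a similarly large effect with that group in place. They also leave open how a phenyl ring at the furan position, or a plain amine in place of methylamino, would read in this assay.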